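The compounds below may be only part of what the source reports. "The series", "measured", "known", "first", "only" and "open" are said of these compounds alone.

The measured compounds are, in turn, compound 1 `Cc1ccc2[nH]c(-c3ccc(-c4ccc(-c5cccc(Cl)c5)cc4)cc3)nc2c1`, compound 2 `COc1ccc(-c2ccc(-c3ccc(-c4nc5cc(C)ccc5[nH]4)cc3)cc2)cc1OC` and compound 3 `Oc1cccc2[nH]c(-c3ccc(-c4ccc(-c5cccc(Cl)c5)cc4)cc3)nc12`. In a functional assay on A549 cells (Homo sapiens) for inhibition, read by sulforhodamine B assay (on this read-out higher numbers stand for weaker inhibition of growth and lower numbers for stronger inhibition of growth), compound 1 gives 2800 nM. In this assay compound 2 gives 2100 nM, and compound 3 gives 2400 nM in this assay. All three numbers lie within the usual scatter of one another, so none of them can be set apart from the others.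

Compound 1 and compound 2 differ by one change, (3,4-dimethoxyphenyl in place of 3-chlorophenyl on an aromatic carbon), and this change gave a 1.3-fold lower number from compound 1 to compound 2 (0.12 log units; within the scatter). The unmeasured compound 4 `COc1ccc(-c2ccc(-c3ccc(-c4nc5c(O)cccc5[nH]4)cc3)cc2)cc1OC` carries the same change relative to compound 3, namely (3,4-dimethoxyphenyl in place of 3-chlorophenyl on an aromatic carbon), on a core that is otherwise that of compound 3; the difference between the two cores of compound 1 and compound 3 is not broken down here.

Since the single earlier occurrence of the change produced only a step within the scatter, the step from compound 3 to compound 4 is expected to be of similar size, estimated as a 1.3-fold lower number from compound 3 to compound 4 (0.10 log units; within the scatter). On that basis the value of compound 4 in this assay is estimated at 1900 nM, with a range from 900 nM to 4000 nM.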

Compound 4, concentration for 50% growth inhibition: 1310 nM
The estimate for compound 4 lay 1.5-fold (0.16 log units) above the measured number, and the stated range covers the measured number.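

In this assay, the exchange of 3-chlorophenyl for 3,4-dimethoxyphenyl was seen on two cores, and the two steps cannot be told apart: the same change on two cores in this assay, a 1.3-fold lower number (0.12 log units; within the scatter) from compound 1 to compound 2 and a 1.8-fold lower number (0.26 log units; within the scatter) from compound 3 to compound 4, 1.4-fold (0.14 log units) apart, within the scatter of two such steps. Neither step can be set apart from the scatter, and the same holds for the exchange of 5-methyl-1H-benzimidazol-2-yl for 4-hydroxy-1H-benzimidazol-2-yl, with a 1.6-fold lower number from compound 2 to compound 4 (0.20 log units; within the scatter), and for the newly seen a 1.8-fold lower number from compound 3 to compound 4 (0.26 log units; within the scatter). The pairs are thus consistent with the change carrying over between these two cores, but they do not show that it strengthens growth inhibition on either core, and two cores give no rule for any other core in the series.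

The compounds shown leave open whether an amine or a carboxylic acid in place of the 3,4-dimethoxyphenyl would give a step beyond the scatter. They also leave open whether the change would carry over to a core with a longer chain in place of the hydroxy or methyl group.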